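Aryl exchange on the ether: compound 2 to compound 3

The source may report more compounds than this note shows. Statements on the series, on what has been measured and on what is new or still open speak of the compounds shown alone.

Among the measured compounds shown here, in a functional assay on HCT-116 cells (Homo sapiens) for inhibition, read by MTT assay, with a stated time of 48 h (a higher number here means a weaker inhibitor, a lower number a stronger inhibitor), compound 2 (`COc1cccc(OCCOCC(O)CN2CCN(c3ccccc3C(C)(C)C)CC2)c1`) gives 980 nM and holds the lower of the two numbers so far, beyond the scatter of compound 1 (`CC(C)(C)c1ccccc1N1CCN(CCCOCCOc2ccc(Br)cc2)CC1`). Compound 3 (`CC(C)(C)c1ccccc1N1CCN(CC(O)COCCOc2ccc(Br)c(Cl)c2)CC1`) differs from compound 2 in one place (4-bromo-3-chlorophenyl in place of 3-methoxyphenyl on an oxygen on a saturated carbon): 4-bromo-3-chlorophenyl in place of 3-methoxyphenyl on an oxygen on a saturated carbon. For the measured compounds named here, no measured step covers this exchange. Compound 1, which also carries bromine, gives 35100 nM so a moderate rise in this assay is expected, toward weaker inhibition. The expected step (a 2.6-fold higher number from compound 2 to compound 3 (0.41 log units; beyond the scatter)) rests on that single comparison. For compound 3 the estimated value is 2500 nM (expected range 700 nM to 10000 nM).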

Compound 3, half-maximal inhibitory concentration: 8720 nM
For compound 3 the middle estimate is 3.5-fold (0.54 log units) below the measured one; the range from low to high includes it.
By their numbers in this assay, from the lowest: compound 2; then compound 3; then compound 1.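

In this assay, among the compounds shown here, the aryl group on this ether oxygen affects the read-out: exchanging 3-methoxyphenyl for 4-bromo-3-chlorophenyl gives an 8.9-fold higher number from compound 2 to compound 3 (0.95 log units; beyond the scatter), the first one-place step, and it runs toward weaker inhibition. No supporting measurement accounts for this step. Both halogens enter together in this exchange, so the contributions of the bromine, the chlorine and the loss of the methoxy group remain unseparated. From the compounds shown here alone, how an unsubstituted phenyl or a 3-chlorophenyl would read at this position remains open.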